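This account rests on a few compounds, and the source may have more. Where it says the series, first, only, none or still open, it means among the compounds named here.

Measured compounds in a functional assay on SF-268 cells (Homo sapiens) for antiproliferative activity, read by sulforhodamine B assay, with a stated time of 48 h; a higher number here means a weaker inhibitor of growth, a lower number a stronger inhibitor of growth:
compound 1, `Nc1nn(C(=O)Nc2ccc(Cc3ccccc3)cc2)c2ccccc12`: 32300 nM
compound 2, `Nc1nn(C(=O)Nc2ccc(Cc3ccccc3)cc2)c2ccc(Cl)cc12`: 47700 nM

Among the compounds with values here, of the two numbers, the one for compound 2 is the larger, but the step of a 1.5-fold higher number from compound 1 to compound 2 (0.17 log units; within the scatter) lies within the scatter, so neither compound can be called the weaker inhibitor of growth on this evidence.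

Compound 3, `Nc1ccc2c(c1)c(N)nn2C(=O)Nc1ccc(Cc2ccccc2)cc1`, differs from compound 2 by amino in place of chloro on an aromatic carbon. Within the data shown here, the only measured step at this carbon, a 1.5-fold higher number from compound 1 to compound 2 (0.17 log units; within the scatter), replaced hydrogen by chloro and stayed within the scatter. Among the measured compounds shown here, no step from chloro to amino, or from hydrogen to amino, has been measured, so the precedent is thin; what there is gives no ground for expecting movement beyond the scatter in this assay. For compound 3 the estimate is therefore 36000 nM, with a range from 14000 nM to 90000 nM. The step of a 1.3-fold lower number from compound 2 to compound 3 (0.12 log units; within the scatter) is thus expected to be no change beyond the scatter.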

Compound 3, concentration for total growth inhibition: 30700 nM
Beside the measured number, compound 3's estimate is 1.2-fold (0.07 log units) above it, within the range that was stated.
By their numbers in this assay, from the lowest: compounds 3, 1 and 2 (each within the scatter of the next).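

In this assay, this aromatic carbon now carries a third substituent, and amino gives a 1.6-fold lower number from compound 2 to compound 3 (0.19 log units; within the scatter) and a 1.1-fold lower number from compound 1 to compound 3 (0.02 log units; within the scatter). Together with the earlier chloro step, these results leave hydrogen, chloro and amino unseparated at this position in this assay. The exchange of chloro for amino also introduces a hydrogen-bond donor and acceptor, as counted for the two groups, without a step beyond the scatter; no supporting measurement bears on why the three compounds fall together.

Still open, as far as these compounds go, is whether a carboxylic acid, a methoxy group or a longer alkyl chain on this carbon would give a step beyond the scatter. The compounds shown also leave open whether changes elsewhere in the shared structure would separate compounds in this assay.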